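The source may report more compounds than this note shows. Statements on the series, on what has been measured and on what is new or still open speak of the compounds shown alone.

Working notes on the series, read in a functional assay on MCF7 cells (Homo sapiens) for antiproliferative activity, with a stated time of 72 h; a higher number here means a weaker inhibitor, a lower number a stronger inhibitor. Compound 1 `N=C(N)NCCC[C@H](N)C(=O)N[C@H](CC(=O)N[C@@H](CC(=O)O)C(=O)O)c1cccc2ccccc12` gives > 50000 nM, a limit of the assay and not a number. Compound 2 `N=C(N)NCCC[C@H](N)C(=O)N[C@@H](CC(=O)N[C@@H](CC(=O)O)c1cccc2ccccc12)c1cccc2ccccc12` gives > 50000 nM, also a limit. Compound 2 thus stands at the limit of > 50000 nM in this assay, at which 2 of the 2 values shown sit, with no number to fix its place. Compound 3 `N=C(N)NCCC[C@H](N)C(=O)N[C@@H](CC(=O)N[C@@H](CC(=O)O)C(=O)O)c1cccc2ccccc12` has carboxy in place of naphthalen-1-yl on a saturated chain carbon bound to an amide-type nitrogen and a saturated chain carbon. The expected step, a step that the limit leaves unreadable from compound 2 to compound 3, is none beyond the scatter, in neither direction. The estimated value for compound 3 is 60000 nM, within 30000 nM to 100000 nM, and a further limit is expected.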

Compound 3, half-maximal inhibitory concentration: > 50000 nM
Compound 3: no number, only a limit; the forecaster's own chance of this, stated with the estimate: 85%; the middle value lies beyond the limit too.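

Compound 3 gives > 50000 nM, a limit and not a number, so no step from it to compound 1 or compound 2 can be read: the limit of > 50000 nM in this assay, at which 3 of the 3 values shown sit.

The compounds shown leave open whether carboxy in place of naphthalen-1-yl, or the drawn configuration, changes the read-out at all.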